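Removing the carbonyl linker from the shared core

A few compounds are considered here, and "the series" means these few. Any claim that something is new, unique, unknown or untested is made for them only; others in the source may bear on it.

Compound 2 `COc1ccc(-c2nc(CNC(=O)N3CCOCC3)sc2-c2ccc(OC)cc2)cc1` stands at 660 nM in a functional assay with Oryctolagus cuniculus as the target (on this read-out lower numbers stand for stronger inhibition and higher numbers for weaker inhibition), the highest of the two numbers shown. Compound 1 `COc1ccc(-c2nc(CNC(=O)C3=NNC(=O)CC3)sc2-c2ccc(OC)cc2)cc1` gives 55 nM in this assay. Compound 3 `COc1ccc(-c2nc(/C=C/C(=O)N3CCN(C)CC3)sc2-c2ccc(OC)cc2)cc1` returns only a limit in this assay, > 1000 nM. One step between measured compounds is known, a 12-fold higher number from compound 1 to compound 2 (1.08 log units; beyond the scatter), and it concerns the ring on the carbonyl carbon while the carbonyl and the amide hydrogen stay in place.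

Compound 4 `COc1ccc(-c2nc(C3=CCN(C)CC3)sc2-c2ccc(OC)cc2)cc1` differs from compound 2 by a group of 7 heavy atoms (6 carbon, 1 nitrogen; one six-membered non-aromatic ring with 1 hetero atom) in place of a group of 10 heavy atoms (6 carbon, 2 nitrogen, 2 oxygen; one six-membered non-aromatic ring with 2 hetero atoms), on an aromatic carbon. Going by the values given here, no measured step touches this change, since the carbonyl and the hydrogen-bond donor of compound 2 leave and the new ring sits directly on the aromatic carbon. The nearest pointer is that the limit of > 1000 nM in this assay, at which 1 of the 3 values shown sits, is reached by compound 3, the one compound shown without the amide hydrogen. Compound 4 is therefore expected to weaken, with a 3.8-fold higher number from compound 2 to compound 4 (0.58 log units; beyond the scatter) the estimated step. Compound 4 is estimated at 2500 nM, expected between 500 nM and 10000 nM, with a real chance that only a limit is reported.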

Compound 4, half-maximal inhibitory concentration: < 10 nM
Compound 4: no number, only a limit (the forecaster's own chance of this, stated with the estimate: 55%); middle value at least 250-fold (2.39 log units) from the limit.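

Compound 4 gives < 10 nM in this assay, which is a limit of the assay and not a number. The change reads as an at least 66-fold lower number from compound 2 to compound 4 (1.81 log units; beyond the scatter), so the aromatic carbon next to the ring nitrogen and next to the ring sulfur tolerates loss of the (((morpholin-4-yl)carbonyl)amino)methyl group with its amide hydrogen and carbonyl. The earlier step, a 12-fold higher number from compound 1 to compound 2 (1.08 log units; beyond the scatter), varied only the ring on the carbonyl carbon, whereas this one shows that a group with 0 hydrogen-bond donors, placed directly on the aromatic carbon, can give the lowest value shown.

The compounds shown do not separate the contributions of the ring double bond, the methyl on the ring nitrogen and the direct attachment. A saturated piperidine, the ring amine without its methyl, or a methylene spacer before the ring would address these points.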